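The source may hold more compounds than are shown below. What is called first, only, known or untested is meant among the compounds shown, and "the series" means these compounds.

Working notes on the series. The shared core is that of compound 1 `CCCCCCCCNc1nc(SCc2ccc(C(F)(F)F)cc2)nc2ccccc12`, which in a functional assay on HGC-27 cells (Homo sapiens) for cytotoxicity, read by MTT assay, with a stated time of 72 h (on this read-out higher numbers stand for weaker inhibition and lower numbers for stronger inhibition), gives 13400 nM. Compound 2 `FC(F)(F)c1ccc(CSc2nc(Nc3ccccc3C(F)(F)F)c3ccccc3n2)cc1` carries 2-(trifluoromethyl)phenyl on a nitrogen on the aromatic ring. In this assay compound 2 reaches only a limit of the measurement, > 50000 nM. Compound 3 `FC(F)(F)c1ccc(CSc2nc(Nc3ccccc3Cl)c3ccccc3n2)cc1` carries 2-chlorophenyl on that nitrogen. In this assay compound 3 likewise stops at a limit, > 50000 nM. Two of the three values thus sit at the limit of > 50000 nM in this assay, at which 2 of the 3 values shown sit, so compound 3 stands no better than the weakest end of what the numbers show. The two aryl replacements read as an at least 3.7-fold higher number from compound 1 to compound 2 (0.57 log units; beyond the scatter) and an at least 3.7-fold higher number from compound 1 to compound 3 (0.57 log units; beyond the scatter), while the comparison between the aryl pair is a step that the two limits leave unreadable from compound 2 to compound 3.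

Compound 4 `COc1ccccc1Nc1nc(SCc2ccc(C(F)(F)F)cc2)nc2ccccc12` differs from compound 3 by methoxy in place of chloro on an aromatic carbon. Among the compounds with values here, no measured step changes this aryl substituent in a readable way; the only steps that bear on the aryl group are the two from octyl to an aryl, each at least modest toward higher numbers. Compound 4 is therefore expected to remain at or near the limit in this assay, with an estimate of 45000 nM spanning 15000 nM to 120000 nM. The expected step is an at least 1.1-fold lower number from compound 3 to compound 4 (0.04 log units; that floor lies within the scatter), none beyond the scatter.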

Compound 4, half-maximal inhibitory concentration: > 50000 nM
Compound 4 gave a limit, no number (the forecaster's own chance of this, stated with the estimate: 60%); middle value at least 1.1-fold (0.04 log units) away from the limit.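

Compound 4 also stops at a limit in this assay, so methoxy in place of chloro on the aromatic carbon still yields no number, and a third aryl group on that nitrogen joins the other two at the same limit: the limit of > 50000 nM in this assay, at which 3 of the 4 values shown sit. The step from octyl to 2-methoxyphenyl on that nitrogen is an at least 3.7-fold higher number from compound 1 to compound 4 (0.57 log units; beyond the scatter), in the same direction as the two earlier steps from octyl to an aryl group. All steps among compound 2, compound 3 and compound 4 join two limits and cannot be read.

On these data alone, whether any aryl group on that nitrogen can give a measured number stays open. So does how a chain longer than octyl, or an amine or a carboxylic acid at the end of that chain, would read.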